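A few compounds are considered here, and "the series" means these few. Any claim that something is new, unique, unknown or untested is made for them only; others in the source may bear on it.

Measured compounds:
compound 1 `CC1(C)Cc2c(sc(NC(=O)c3ccccc3O)c2C(N)=O)C(C)(C)O1`: in an assay on cells for positive allosteric modulation of Cystic fibrosis transmembrane conductance regulator variant G551D (Homo sapiens), with stated times of 10 min and 2 min, in the presence of a further agent that is not named here (on this read-out higher numbers stand for an effect only at larger amounts of compound and lower numbers for an effect already at smaller amounts), compound 1 gives 162 nM.
compound 2 `Cc1cc(C(=O)Nc2sc3c(c2C(N)=O)CC(C)(C)OC3(C)C)[nH]n1`: in this assay compound 2 gives 590 nM.

Among the compounds with values here, compound 2 stands at the higher of the two numbers; the step of a 3.6-fold higher number from compound 1 to compound 2 (0.56 log units; beyond the scatter) separates it from compound 1, its only neighbour. Compound 3 `Cc1n[nH]c(C(=O)Nc2sc3c(c2C(N)=O)CC(C)(C)OC3(C)C)c1Cl` has not yet been measured. It differs from compound 2 by chloro in place of hydrogen on an aromatic carbon, the ring concerned being the five-membered aromatic ring with two nitrogens that carries the methyl group and the large group. Within the data shown here, only one measured step exists, a 3.6-fold higher number from compound 1 to compound 2 (0.56 log units; beyond the scatter), and it exchanges the entire group on the carbonyl carbon; it says nothing about a chloro substituent entering a ring that is otherwise kept. Among the measured compounds shown here, no measured step covers a chloro for hydrogen swap, so the numbers give no direction. For compound 3 a step of a 1.2-fold lower number from compound 2 to compound 3 (0.07 log units; within the scatter) is expected, within the scatter, with the number staying close to that of compound 2. Compound 3 is accordingly estimated at 500 nM, with a range from 200 nM to 1500 nM.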

Compound 3, half-maximal effective concentration: 199 nM
Compound 3: the middle estimate sits 2.5-fold (0.40 log units) above what was measured; the whole stated range lies above it.
By their numbers in this assay, from the lowest: compounds 1 and 3 (each within the scatter of the next); then compound 2.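

In this assay, within the data shown here, chloro in place of hydrogen on an aromatic carbon gives a 3.0-fold lower number from compound 2 to compound 3 (0.47 log units; beyond the scatter) and is the first change confined to a single atom position, so this carbon of the five-membered aromatic ring with 2 nitrogen can be read on its own, which the earlier exchange of the entire group on the carbonyl carbon did not allow. With chloro in place, the exchange of that entire group gives a 1.2-fold higher number from compound 1 to compound 3 (0.09 log units; within the scatter) and lies within the scatter, whereas without chloro the corresponding exchange gives a 3.6-fold higher number from compound 1 to compound 2 (0.56 log units; beyond the scatter) and lies beyond it, so in this series the gap between the 2-hydroxyphenyl compound and the five-membered ring compound depends on what this carbon carries. Nothing available here bears on what lies behind the effect of the chloro.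

As far as these compounds go, whether the step belongs to chloro itself or would also follow from another group on this carbon, such as bromo, methoxy or a nitrile, remains open. Also open, from the compounds shown here alone, is whether the step carries over when the methyl group on the same ring gives way to a longer chain such as ethyl.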